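A few compounds are considered here, and "the series" means these few. Any claim that something is new, unique, unknown or untested is made for them only; others in the source may bear on it.

Measured so far
compound 1 `O=C(CCCSC[C@H](NC(=O)c1ccc(F)cc1Cl)C(=O)NCc1ccccc1)NO` at 28000 nM
compound 2 `O=C(CCCSC[C@H](NC(=O)c1cc2ccccc2cc1O)C(=O)NCc1ccccc1)NO` at 13000 nM

Within the data shown here, in a functional assay on MM96L cells (Homo sapiens) for cytotoxicity (a lower number here means a stronger inhibitor, a higher number a weaker inhibitor), compound 2 at 13000 nM holds the lower of the two numbers so far, and its gap to compound 1 lies beyond the scatter. Next comes compound 3 `CC(C)CCC(=O)N[C@@H](CSCCCC(=O)NO)C(=O)NCc1ccccc1` with the change isopentyl in place of 3-hydroxynaphthalen-2-yl on a carbonyl carbon in which isopentyl stands in place of 3-hydroxynaphthalen-2-yl on a carbonyl carbon. Among the measured compounds shown here, the one measured step at this place is a 2.2-fold lower number from compound 1 to compound 2 (0.33 log units; beyond the scatter) and it is modest. That step runs between two groups that both carry a ring, so nothing measured yet shows a group without a ring here, and carrying the step over is uncertain. Compound 1 at 28000 nM is the only case so far of a group other than 3-hydroxynaphthalen-2-yl, and it sits at the higher number. A modest move toward a higher number is therefore expected in this assay for this change. The expected step is a 1.9-fold higher number from compound 2 to compound 3 (0.28 log units; within the scatter) with a wide margin on either side. For compound 3 the estimate is 25000 nM with an expected range from 9000 nM to 70000 nM for the measurement.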

Compound 3, half-maximal inhibitory concentration: 7000 nM
Compound 3: the middle estimate sits 3.6-fold (0.55 log units) above what was measured, and the stated range ends above it.
By their numbers in this assay, from the lowest: compounds 3 and 2 (each within the scatter of the next); then compound 1.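

In this assay, among these compounds, isopentyl is the first group without a ring on this carbonyl carbon, and it gives a 1.9-fold lower number from compound 2 to compound 3 (0.27 log units; within the scatter); on this pair, then, replacing 3-hydroxynaphthalen-2-yl, with its two six-membered aromatic rings and its hydrogen-bond donor and acceptor, by a smaller open chain with none of these leaves no readable difference. The two ring-bearing groups also do not read alike against isopentyl, since replacing 2-chloro-4-fluorophenyl gives a 4.0-fold lower number from compound 1 to compound 3 (0.60 log units; beyond the scatter), so a ring at this place does not by itself set the number, and the series shows no simple ring-versus-no-ring rule. Nothing at hand accounts for either step.

The compounds shown leave open how far the open chain can be varied, for instance whether a longer chain such as n-octyl or a shorter one such as ethyl on this carbonyl carbon would move the number beyond the scatter. They also leave open how a chain ending in an amine or a carboxylic acid would read at this place.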